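Chain extension at two sites in a triazene antiproliferative series

The compounds below may be only part of what the source reports. "The series", "measured", "known", "first", "only" and "open" are said of these compounds alone.

Values in a functional assay on L1210 cells (Mus musculus) for antiproliferative activity; on this read-out higher numbers stand for higher potency (the scale is a negative logarithm) and lower numbers for lower potency:
compound 1 `CCCCOC(=O)c1[nH]cnc1/N=N/N(C)C`: 3.53
compound 2 `CCCCCCCCOC(=O)c1[nH]cnc1/N=N/N(C)C`: 3.06
compound 3 `CCCCN(C)/N=N/c1ccc(C(N)=O)cc1`: 3.47

One counted change occurs twice in the series. Between the measured pair it reads butyl in place of hydrogen on a saturated chain carbon, four bonds along the chain from an oxygen next to a carbonyl group and gives a number 0.47 log units lower from compound 1 to compound 2 (beyond the scatter). Compound 4 `CCCCCCCCN(C)/N=N/c1ccc(C(N)=O)cc1` carries the same kind of change on the core of compound 3: butyl in place of hydrogen on a saturated chain carbon, four bonds along the chain from an amine nitrogen. The place is not identical: in the measured pair the chain carbon sits four bonds along the chain from an oxygen next to a carbonyl group, here four bonds along the chain from an amine nitrogen. How the core of compound 3 differs from the core of compound 1 is not broken down here; compound 3 and compound 1 sit within the scatter of each other.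

For compound 4 a step of a number 0.42 log units lower from compound 3 to compound 4 (beyond the scatter) is expected, resting on the measured step of a number 0.47 log units lower from compound 1 to compound 2 (beyond the scatter). In this assay compound 4 is therefore estimated at 3.05, between 2.6 and 3.5.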

Compound 4, logarithm of the reciprocal of the active concentration, log(1/C): 2.84
Compound 4: the middle estimate sits 0.21 log units above what was measured; the range from low to high includes it.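

On the core of compound 3, butyl in place of hydrogen on a saturated chain carbon gives a number 0.63 log units lower from compound 3 to compound 4 (beyond the scatter) in this assay. The change carries from one core to the other with the same direction and a comparable size: the same change on two cores in this assay, a number 0.47 log units lower (beyond the scatter) from compound 1 to compound 2 and a number 0.63 log units lower (beyond the scatter) from compound 3 to compound 4, 0.16 log units apart, within the scatter of two such steps

Among the compounds shown here, this rests on only two pairs in one assay, with the chain on an oxygen next to a carbonyl group in one pair and on an amine nitrogen in the other; it does not show why the numbers fall or that the step would hold on any further core. Still open, as far as these compounds go, is how either core responds to a longer chain such as dodecyl, or to a chain ending in an amine or a carboxylic acid.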